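Compound 3 to compound 4: a new group on the chain

A few compounds are considered here, and "the series" means these few. Any claim that something is new, unique, unknown or untested is made for them only; others in the source may bear on it.

In a functional assay on K562 cells (Homo sapiens) for antiproliferative activity, read by MTT assay, with a stated time of 24 h (on this read-out lower numbers stand for stronger inhibition and higher numbers for weaker inhibition), compound 1 `COc1cccc(/C=C/C(=O)c2ccc(OC)c3c2OC(C)(C)C=C3)c1` gives > 10000 nM as a limit of the assay, not a number. Compound 2 `COc1ccc(C(=O)/C=C/c2ccc(F)cc2)c2c1C=CC(C)(C)O2` gives > 10000 nM as a limit too. Compound 3 `COc1ccc(C(=O)/C=C/c2cccc(F)c2)c2c1C=CC(C)(C)O2` gives > 10000 nM as a further limit. Compound 3 therefore stands with the rest of the series, at the limit of > 10000 nM in this assay, at which 3 of the 3 values shown sit, and without a measured potency of its own.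

Compound 4 `COc1ccc(C(=O)/C=C/c2ccc(N(C)C)cc2)c2c1C=CC(C)(C)O2` carries 4-(dimethylamino)phenyl in place of 3-fluorophenyl on a double-bonded chain carbon bound to a double-bonded chain carbon, and the count for this change reads 4-(dimethylamino)phenyl in place of 3-fluorophenyl on a double-bonded chain carbon bound to a double-bonded chain carbon in full.

Going by the values given here, three measured steps touch the same part of the molecule: a step that the two limits leave unreadable from compound 1 to compound 2 and a step that the two limits leave unreadable from compound 1 to compound 3 and a step that the two limits leave unreadable from compound 2 to compound 3 are the ones available. Among the compounds with values here, none of them has a readable size, so they give neither a magnitude nor a direction for the new step in this assay and show only that three different aryl groups all leave the series at the limit.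

The expected step of a number no higher from compound 3 to compound 4 (the limit leaves the size open) is estimated to stay within the scatter with no favoured direction, and another limit is the likeliest report. For compound 4 the estimate is 10000 nM with an expected range from 2500 nM to 30000 nM as the working figure.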

Compound 4, half-maximal inhibitory concentration: 3500 nM
Estimate against measurement, compound 4: 2.9-fold (0.46 log units) above; the range from low to high includes it.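

In this assay, the aryl group on a double-bonded chain carbon bound to a double-bonded chain carbon gives its first readable change, as 4-(dimethylamino)phenyl in place of 3-fluorophenyl gives an at least 2.8-fold lower number from compound 3 to compound 4 (0.45 log units; beyond the scatter). The same gain appears against the other two aryl groups, with dimethylamino in place of fluoro on an aromatic carbon giving an at least 2.8-fold lower number from compound 2 to compound 4 (0.45 log units; beyond the scatter) and 4-(dimethylamino)phenyl in place of 3-methoxyphenyl giving an at least 2.8-fold lower number from compound 1 to compound 4 (0.45 log units; beyond the scatter). The steps among compound 1, compound 2 and compound 3 cannot be read, so the only measured potency at this position belongs to compound 4, while the other three share a single result, which is a limit and not a number: the limit of > 10000 nM in this assay, at which 3 of the 4 values shown sit.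

Each readable step starts from a limit, so the true size of the gain stays open, and no cause for it can be assigned from these compounds. As far as these compounds go, whether the gain is specific to dimethylamino also stays open, and a 4-aminophenyl, a 4-(morpholin-4-yl)phenyl or a 3-(dimethylamino)phenyl group at the same place would separate the nature of the amine from where it sits on the aryl ring.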